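The source may report more compounds than this note shows. Statements on the series, on what has been measured and on what is new or still open speak of the compounds shown alone.

Compound 1 `C[C@H]1[C@H](NCc2ccsc2)C[C@H]2C[C@@H]1C2(C)C` is tested in an ADME assay on MDCK cells (Canis lupus familiaris) for cytotoxicity, read by microscopy, with a stated time of 48 h (a lower number here means that less compound is tolerated, a higher number that more compound is tolerated), where compound 1 gives 50000 nM. Among the three compounds measured, this is the highest number. Among the compounds with values here, compound 2 `C[C@H]1[C@H](NCc2sccc2-c2ccsc2)C[C@H]2C[C@@H]1C2(C)C` gives 12500 nM in this assay, and compound 3 `C[C@H]1[C@H](NCc2sccc2C2CCCCC2)C[C@H]2C[C@@H]1C2(C)C` gives 1560 nM; between those two the change is an 8.0-fold lower number from compound 2 to compound 3 (0.90 log units; beyond the scatter), which is the only step between measured neighbours differing in a single place. It concerns cyclohexyl in place of thiophen-3-yl on an aromatic carbon, a different kind of change from the one examined here.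

Compound 4 `Cc1csc(CN[C@@H]2C[C@H]3C[C@@H]([C@H]2C)C3(C)C)c1` differs from compound 1 in one respect: 4-methylthiophen-2-yl in place of thiophen-3-yl on a saturated chain carbon bound to an amine nitrogen. Within the data shown here, no measured pair shows this change directly. The gap between compound 1 and compound 2 shows that enlarging the group on the saturated chain carbon lowers the number, but that enlargement was larger than a single methyl and a shift of the attachment point. Among the measured compounds shown here, the one recorded step bears on the question only loosely, so the account expects a small downward movement at most, likely within the scatter. Compound 4 is therefore estimated in this assay at 35000 nM, with a range from 12500 nM to 60000 nM, which corresponds to an expected step of a 1.4-fold lower number from compound 1 to compound 4 (0.15 log units; within the scatter).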

Compound 4, minimum cytotoxic concentration: 12500 nM
Beside the measured number, compound 4's estimate is 2.8-fold (0.45 log units) above it; low and high end bracket the measured number.
By their numbers in this assay, from the lowest: compound 3; then compounds 2 and 4 (each within the scatter of the next); then compound 1.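

In this assay, within the data shown here, the step from the thiophen-3-yl group to 4-methylthiophen-2-yl is a 4.0-fold lower number from compound 1 to compound 4 (0.60 log units; beyond the scatter), so this place, on a saturated chain carbon bound to an amine nitrogen, responds to a small exchange and not only to the larger alteration seen in the earlier compounds. The step goes beyond the scatter even though the entering and leaving groups match in much of what can be counted: each has one five-membered aromatic ring with 1 hetero atom, 0 hydrogen-bond donors, 1 hydrogen-bond acceptor and no net charge, and they differ by 6 heavy atoms against 5. No measurement available here accounts for why the number falls.

The change joins a methyl group with a different point of attachment on the thiophene, and the compounds shown do not separate the two, so it remains open how much of the step belongs to each; a plain thiophen-2-yl group in this place would address that question. Also open, going by these compounds, is how the number would respond to a phenyl ring here, or to a carboxylic acid or an amine carried on the thiophene.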